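Purine series: aryl swap on the pyridine of compound 3

The source may report more compounds than this note shows. Statements on the series, on what has been measured and on what is new or still open speak of the compounds shown alone.

Measured so far:
compound 1 `COc1ccccc1-c1ccc(Nc2nc(N[C@H]3CC[C@H](N)CC3)nc3c2ncn3C2CCCC2)cc1` — 2350 nM
compound 2 `Nc1ccccc1-c1ccc(Nc2nc(N[C@H]3CC[C@H](N)CC3)nc3c2ncn3C2CCCC2)cc1` — 677 nM
compound 3 `N[C@H]1CC[C@H](Nc2nc(Nc3ccc(-c4cccs4)nc3)c3ncn(C4CCCC4)c3n2)CC1` — 477 nM

In an ADME assay on CCRF-CEM cells (Homo sapiens) for inhibition, read by fluorescence and resazurin assay, with a stated time of 72 h (a lower number here means a stronger inhibitor of growth, a higher number a weaker inhibitor of growth), compound 3 gives the smallest of the three numbers; its gap to compound 2 is within the scatter, while its gap to compound 1 lies beyond it. Among the measured compounds shown here, the one step measured so far, a 3.5-fold lower number from compound 1 to compound 2 (0.54 log units; beyond the scatter), concerns a substituent on the phenyl of compound 1 and compound 2, not the pyridine of compound 3.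

Compound 4 `COc1ccc(-c2ccc(Nc3nc(N[C@H]4CC[C@H](N)CC4)nc4c3ncn4C3CCCC3)cn2)cc1` differs from compound 3 by 4-methoxyphenyl in place of thiophen-2-yl on an aromatic carbon. For the measured compounds named here, no measured pair shows this change; the step from compound 1 to compound 2 only indicates that substituents on the distal aryl can move the number by a modest amount, and it gives no direction for the present swap. Compound 3 at 477 nM is therefore the only anchor, and the expectation is a step of modest size at most, with direction uncertain; a slight rise in the number is taken as the central guess.

Compound 4 is estimated at 800 nM, range 300 nM to 2500 nM, which corresponds to an expected step of a 1.7-fold higher number from compound 3 to compound 4 (0.22 log units; within the scatter).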

Compound 4, concentration for 50% growth inhibition: 544 nM
For compound 4 the middle estimate is 1.5-fold (0.17 log units) above the measured one; the range from low to high includes it.
By their numbers in this assay, from the lowest: compounds 3, 4 and 2 (each within the scatter of the next); then compound 1.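

At the aromatic carbon next to the ring nitrogen, para to a large group, a six-membered aromatic ring of carbon only can replace a five-membered aromatic ring with 1 hetero atom without a separable effect in this assay: 4-methoxyphenyl in place of thiophen-2-yl gives a 1.1-fold higher number from compound 3 to compound 4 (0.06 log units; within the scatter). Among the compounds shown here, this is the first single-place comparison at this position, and it sets a change of ring type and ring size against the earlier substituent change on the phenyl, a 3.5-fold lower number from compound 1 to compound 2 (0.54 log units; beyond the scatter), which lay beyond the scatter. Nothing measured explains why this swap leaves the two compounds inseparable in this growth read-out.

On these data alone, with only thiophen-2-yl and 4-methoxyphenyl at this position, it remains open whether any group placed here can move the number beyond the scatter, for example a carboxylic acid or a dimethylaminomethyl group on the phenyl ring. As far as these compounds go, it is also open whether amino in place of methoxy would give a step of similar size on the 4-methoxyphenyl of compound 4, where the substituent sits differently from that of compound 1.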